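Adding a trifluoromethyl to the chlorobenzyl ring of compound 2

The compounds below may be only part of what the source reports. "The series", "measured", "known", "first", "only" and "open" are said of these compounds alone.

Three sulfonamides built on the same core have been tested in a functional assay on Capan-2 cells (Homo sapiens) for inhibition, read by MTT assay, with a stated time of 72 h; on this read-out lower numbers stand for stronger inhibition of growth and higher numbers for weaker inhibition of growth. Compound 1 `O=S(=O)(NCCCCNCc1ccc(Br)cc1)c1cc(C(F)(F)F)cc(C(F)(F)F)c1` gives 1900 nM, compound 2 `O=S(=O)(NCCCNCc1ccc(Cl)cc1)c1cc(C(F)(F)F)cc(C(F)(F)F)c1` gives 2700 nM, and compound 3 `O=S(=O)(NCCNCc1ccc(-c2ccccc2)cc1)c1cc(C(F)(F)F)cc(C(F)(F)F)c1` gives 2400 nM. Compound 2 holds the highest of the three numbers, yet its gaps to the other two are within the scatter, so the three stand level. Among the measured compounds shown here, the one step between compounds differing in a single place, a 1.4-fold higher number from compound 1 to compound 2 (0.15 log units; within the scatter), concerns the chain and the halogen, not a further substituent on the benzyl ring.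

Compound 4 `O=S(=O)(NCCCNCc1ccc(Cl)c(C(F)(F)F)c1)c1cc(C(F)(F)F)cc(C(F)(F)F)c1` differs from compound 2 by trifluoromethyl in place of hydrogen on an aromatic carbon. For the measured compounds named here, no measured step tests this change, and the only available step lay within the scatter, so nothing in the data points to a movement beyond the scatter in this assay in either direction. Compound 4 is therefore estimated at 2200 nM, between 900 nM and 5000 nM, which means an expected step of a 1.2-fold lower number from compound 2 to compound 4 (0.09 log units; within the scatter).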

Compound 4, concentration for 50% growth inhibition: 9100 nM
For compound 4 the middle estimate is 4.1-fold (0.62 log units) below the measured one; the measured number lies above the stated range.
By their numbers in this assay, from the lowest: compounds 1, 3 and 2 (each within the scatter of the next); then compound 4.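

In this assay trifluoromethyl in place of hydrogen on the aromatic carbon ortho to the chloro group gives a 3.4-fold higher number from compound 2 to compound 4 (0.53 log units; beyond the scatter) and so is the first step among these compounds that lies beyond the scatter, in the direction of weaker inhibition of growth. The earlier compounds shown here stood level and showed nothing about this carbon, whereas the change from 4-chlorophenyl to 4-chloro-3-(trifluoromethyl)phenyl shows that the read-out is not indifferent to what sits there. Nothing measured here bears on the reason for this step.

The compounds shown leave open whether the weakening belongs to trifluoromethyl alone, as no fluoro, methyl, methoxy or nitrile at this same carbon stands among them. They also leave open whether the same change would move the number similarly on the bromobenzyl ring of compound 1 or on the biphenyl of compound 3.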